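Benzyl in Place of Pyridin-2-yl: Expected Inhibition

The source may hold more compounds than are shown below. What is called first, only, known or untested is meant among the compounds shown, and "the series" means these compounds.

compound 1 `CCCCCCCCc1ccc(OCC(=O)Cn2nnc(-c3ccncc3)n2)cc1`: 24 nM
compound 2 `CCCCCCCCc1ccc(OCC(=O)Cn2nnc(-c3ccccn3)n2)cc1`: 18 nM

In an assay on microsomes from brain for inhibition of Fatty-acid amide hydrolase 1 (Rattus norvegicus), read by fluorescence and HPLC, with a stated time of 60 min (on this read-out higher numbers stand for weaker inhibition and lower numbers for stronger inhibition), compound 2 and compound 1 stand at two numbers that do not differ beyond the scatter, the step being a 1.3-fold lower number from compound 1 to compound 2 (0.12 log units; within the scatter). Compound 3 `CCCCCCCCc1ccc(OCC(=O)Cn2nnc(Cc3ccccc3)n2)cc1` differs from compound 2 by benzyl in place of pyridin-2-yl on an aromatic carbon. Among the compounds with values here, the single measured step, a swap of pyridin-4-yl for pyridin-2-yl, does not bear on this exchange, and no measured pair shows a change of this kind. Compound 3 is therefore expected at 35 nM (range 9 nM to 140 nM), an expected step of a 1.9-fold higher number from compound 2 to compound 3 (0.29 log units; within the scatter) that need not exceed the scatter.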

Compound 3, half-maximal inhibitory concentration: 66 nM
Compound 3: middle estimate off by 1.9-fold (0.28 log units), on the low side; low and high end bracket the measured number.
By their numbers in this assay, from the lowest: compounds 2 and 1 (each within the scatter of the next); then compound 3.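

In this assay, the group on this aromatic carbon does matter: benzyl in place of pyridin-2-yl gives a 3.7-fold higher number from compound 2 to compound 3 (0.56 log units; beyond the scatter), and benzyl in place of pyridin-4-yl gives a 2.8-fold higher number from compound 1 to compound 3 (0.44 log units; beyond the scatter), whereas exchanging the two pyridine groups stayed within the scatter. Inhibition is therefore weaker with benzyl than with either pyridine group. No supporting measurement accounts for this difference. Benzyl differs from both pyridine groups in two respects, an all-carbon ring and one more heavy atom, and the compounds shown do not separate these. A phenyl group on the same carbon would separate them.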